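Cytotoxicity notes on the sulfonate and acrylate esters

The source may report more compounds than this note shows. Statements on the series, on what has been measured and on what is new or still open speak of the compounds shown alone.

Compound 1, `O=c1cc(N2CCN(CC3CCC(OS(=O)(=O)c4cccnc4)CC3)CC2)sc2c([N+](=O)[O-])cc(C(F)(F)F)cc12`: in an ADME assay on Vero cells (Chlorocebus sabaeus) for cytotoxicity, read by MTT assay, with a stated time of 48 h (a lower number here means a stronger inhibitor, a higher number a weaker inhibitor), compound 1 gives > 64 ug/mL, a limit of the assay and not a number.
Compound 2, `O=c1cc(N2CCN(CC3CCC(OS(=O)(=O)c4ccccc4)CC3)CC2)sc2c([N+](=O)[O-])cc(C(F)(F)F)cc12`: in this assay compound 2 gives > 64 ug/mL, likewise a limit.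
Compound 3, `C=CC(=O)OC1CCC(CN2CCN(c3cc(=O)c4cc(C(F)(F)F)cc([N+](=O)[O-])c4s3)CC2)CC1`: in this assay compound 3 gives > 64 ug/mL, likewise a limit.

Compound 1 therefore stands only at a limit in this assay, and every value shown so far sits at the same place: the limit of > 64 ug/mL in this assay, at which 3 of the 3 values shown sit. The steps that touch compound 1 are all unreadable for this reason, namely a step that the two limits leave unreadable from compound 1 to compound 2 and a step that the two limits leave unreadable from compound 1 to compound 3, and the same holds for a step that the two limits leave unreadable from compound 2 to compound 3. None of them shows a direction or a size beyond the scatter.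

Compound 4, `CS(=O)(=O)OC1CCC(CN2CCN(c3cc(=O)c4cc(C(F)(F)F)cc([N+](=O)[O-])c4s3)CC2)CC1`, has not yet been measured. It differs from compound 1 by methyl in place of pyridin-3-yl on a sulfonyl sulfur. The measured steps that bear on it are the ones above; since each is unreadable, no step beyond the scatter is expected in this assay, in either direction. Compound 4 is expected to give about 80 ug/mL, most likely reported once more as a limit, with a range from 40 ug/mL to 200 ug/mL. This estimate means an expected step that the limit leaves unreadable from compound 1 to compound 4.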

Compound 4, half-maximal inhibitory concentration: > 64 ug/mL
Compound 4 gave a limit, no number; the forecaster's own chance of this, stated with the estimate: 85%; the middle value is on the limit's open side.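

Going by these compounds alone, compound 4 gives only a limit, as do compound 1, compound 2 and compound 3, so no step among them can be read in this assay: the limit of > 64 ug/mL in this assay, at which 4 of the 4 values shown sit. The compounds shown leave open whether changing the ester group alters the half-maximal inhibitory concentration in this assay at all.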